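Thiophen-2-yl in place of 3-methoxyphenyl on compound 2

This account rests on a few compounds, and the source may have more. Where it says the series, first, only, none or still open, it means among the compounds named here.

In a functional assay on HCT-116 cells (Homo sapiens) for inhibition, read by sulforhodamine B assay, with a stated time of 48 h, tested at 50 uM (on this read-out lower numbers stand for less inhibition of growth and higher numbers for more inhibition of growth at the one concentration tested), compound 1 (`COc1cccc(/C=C/C(=O)/C=C/c2ccc(OCc3cn(CCOc4cc(=O)oc5ccccc45)nn3)c(OC)c2)c1`) gives 70% on the single concentration tested. Compound 2 (`COc1cccc(/C=C/C(=O)/C=C/c2ccc(OCc3cn(CCCOc4cc(=O)oc5ccccc45)nn3)c(OC)c2)c1`) gives 55% on the same read-out, and compound 3 (`COc1ccccc1/C=C/C(=O)/C=C/c1ccc(OCc2cn(CCCCOc3cc(=O)oc4ccccc34)nn2)c(OC)c1`) gives 43% there. Compound 2 therefore stands second highest of the three, with compound 3 lower and compound 1 higher, and both gaps lie beyond the usual scatter. Among the measured compounds shown here, no two of these three compounds differ in one place only, so no measured step isolates a single structural change, and none speaks directly to the exchange considered here.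

The change from compound 2 to compound 4 (`COc1cc(/C=C/C(=O)/C=C/c2cccs2)ccc1OCc1cn(CCCOc2cc(=O)oc3ccccc23)nn1`) is thiophen-2-yl in place of 3-methoxyphenyl on a double-bonded chain carbon bound to a double-bonded chain carbon with thiophen-2-yl in place of 3-methoxyphenyl on a double-bonded chain carbon bound to a double-bonded chain carbon. The rest of the structure stays the same. For the measured compounds named here, the data hold no measured example of this exchange, so the expectation starts from compound 2 at 55% and stays close to it, with a wide margin. In this assay no step beyond the scatter is expected in either direction. The expected step is a number 3 percentage points lower from compound 2 to compound 4 (within the scatter) and it remains an estimate until measured. Compound 4 is estimated at 52% with an expected range from 36% to 68% on this read-out.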

Compound 4, percent growth inhibition at one concentration: 58%
For compound 4 the middle estimate is 6 percentage points below the measured one; the range from low to high includes it.
By their numbers in this assay, from the lowest: compound 3; then compounds 2 and 4 (each within the scatter of the next); then compound 1.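

In this assay, among the compounds shown here, the exchange of 3-methoxyphenyl for thiophen-2-yl gives a number 3 percentage points higher from compound 2 to compound 4 (within the scatter) and is the only measured step in this set that isolates one structural change. On a double-bonded chain carbon bound to a double-bonded chain carbon, the six-membered aromatic ring of carbon only, with 8 heavy atoms, can therefore be replaced by a five-membered aromatic ring with 1 hetero atom and 5 heavy atoms with no change in growth inhibition beyond the usual scatter. No independent measurement on hand bears on why compound 2 and compound 4 agree.

On these data alone, whether this tolerance extends to furan-2-yl, pyridin-3-yl or a phenyl ring carrying a carboxylic acid at the same place remains open, as does whether the thiophen-2-yl exchange reads the same with the linking chains of compound 1 and compound 3. A read-out at one concentration also leaves open how compound 2 and compound 4 would compare across a range of concentrations.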